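The source may report more compounds than this note shows. Statements on the series, on what has been measured and on what is new or still open speak of the compounds shown alone.

The account begins with compound 3 `N#CC1=C(N)Oc2c(N)cc3nc4ccccc4nc3c2C12C(=O)N(Cc1cnnn1-c1cccc(C(F)(F)F)c1)c1ccccc12`, which carries a 3-(trifluoromethyl)phenyl group on the aromatic nitrogen of its triazole. In an ADME assay on HUVEC cells (Homo sapiens) for antiproliferative activity, read by MTT assay, with a stated time of 48 h (a higher number here means a weaker inhibitor, a lower number a stronger inhibitor), compound 3 gives > 50000 nM, and this is a limit of the assay rather than a number. Its two companions stand in the same place. Compound 1 `N#CC1=C(N)Oc2c(c3nc4ccccc4nc3c3ccccc23)C12C(=O)N(Cc1cnnn1-c1ccc([N+](=O)[O-])cc1)c1ccccc12` gives > 50000 nM in this assay, again a limit. Compound 2 `Cc1ccc(C)c(-n2nncc2CN2C(=O)C3(C(C#N)=C(N)Oc4c3c3nc5ccccc5nc3c3ccccc43)c3ccccc32)c1` gives > 50000 nM in this assay, also a limit. Across the three, (the limit of > 50000 nM in this assay, at which 3 of the 3 values shown sit), so compound 3 cannot be placed above or below either of the others. Among the measured compounds shown here, the single measured change of the aryl on that nitrogen, a step that the two limits leave unreadable from compound 1 to compound 2, is therefore unreadable in size and direction.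

Compound 4 `N#CC1=C(N)Oc2c(N)cc3nc4ccccc4nc3c2C12C(=O)N(Cc1cnnn1-c1c(Cl)cc(Cl)cc1Cl)c1ccccc12` is the next member to be measured. It differs from compound 3 by 2,4,6-trichlorophenyl in place of 3-(trifluoromethyl)phenyl on an aromatic nitrogen. The only measured step that touches the same position, from compound 1 to compound 2, gives no readable size, and compound 3 itself sits at a limit; so nothing among the numbers shown supports a step in either direction. The expected step that the limit leaves unreadable from compound 3 to compound 4 is therefore estimated as none beyond the scatter. Compound 4 is accordingly expected to give 60000 nM in this assay, with a range from 20000 nM to 200000 nM, most probably reported as a limit once more.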

Compound 4, half-maximal inhibitory concentration: 18300 nM
The estimate for compound 4 lay 3.3-fold (0.52 log units) above the measured number; measured number outside the range, below it.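

In this assay, among the compounds shown here, 2,4,6-trichlorophenyl in place of 3-(trifluoromethyl)phenyl on the aromatic nitrogen gives an at least 2.7-fold lower number from compound 3 to compound 4 (0.43 log units; beyond the scatter), so the group at this place can bring the read-out off the limit, which the earlier compounds could not show. That step marks only the smallest size the change can have, as compound 3 gives > 50000 nM, which is a limit of the assay and not a number. The two groups match in having one six-membered aromatic ring of carbon only, with no hydrogen-bond donors or acceptors and no net charge, yet compound 4 alone carries a number, while the rest remain at the limit: the limit of > 50000 nM in this assay, at which 3 of the 4 values shown sit.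

Going by these compounds, it remains open whether the step needs all three chlorine atoms of the 2,4,6-trichlorophenyl group, or whether a plain phenyl, a 4-chlorophenyl or a 4-methoxyphenyl group at the same place would also give a number. Also open, on these data alone, is whether 2,4,6-trichlorophenyl would give a similar step on the core of compound 1, which differs from that of compound 4 in more than one place.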